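The source may report more compounds than this note shows. Statements on the series, on what has been measured and on what is new or still open speak of the compounds shown alone.

Three urea- or thiourea-linked compounds built on a shared dihydrobenzopyran core have been measured in a functional assay on A2780 cells (Homo sapiens) for inhibition, with a stated time of 72 h; on this read-out lower numbers stand for stronger inhibition and higher numbers for weaker inhibition. Compound 1 `CC1(C)CCOc2ccc(NC(=S)Nc3ccc(OC(F)(F)F)cc3)cc21` gives 4300 nM. Compound 2 `CCC1(CC)CC(C)(C)Oc2ccc(NC(=O)Nc3ccc(C(F)(F)F)cc3)cc21` gives 2430 nM. Compound 3 `CC1(C)CC(C)(C)c2cc(NC(=O)Nc3ccc([N+](=O)[O-])cc3)ccc2O1` gives 4100 nM, the second highest of the three numbers, although its distances to compound 1 and to compound 2 both lie within the scatter of the measurement, so nothing separates the three compounds on this read-out.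

Compound 4 `CC1(C)CC(C)(C)c2cc(NC(=O)Nc3ccc(C#N)cc3)ccc2O1` has not yet been measured in this assay. It differs from compound 3 in one place: cyano in place of nitro on an aromatic carbon. Among the measured compounds shown here, no measured pair in the set shows this change, so there is no step to lean on. Given that the three measured compounds, with their differing ring substitution and linker, all fall within the scatter of one another, no step beyond the scatter is expected in this assay.

Compound 4 is therefore expected to give about 4000 nM, with a range from 1500 nM to 11000 nM. The estimated step of a 1.0-fold lower number from compound 3 to compound 4 (0.01 log units; within the scatter) is expected to remain within the scatter.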

Compound 4, half-maximal inhibitory concentration: 4700 nM
Estimate against measurement, compound 4: 1.2-fold (0.07 log units) below; low and high end bracket the measured number.
By their numbers in this assay, from the lowest: compounds 2, 3, 1 and 4 (each within the scatter of the next).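

In this assay, among the compounds shown here, putting cyano in place of nitro gives a 1.1-fold higher number from compound 3 to compound 4 (0.06 log units; within the scatter) and so stays within the scatter; this is the first step in the set between two compounds that differ in one place. On this aromatic carbon of the six-membered ring, para to a large group, the two groups therefore cannot be told apart on this read-out. No measurement shown here offers an explanation for this result. 

Going by these compounds, whether another kind of group on this carbon, such as an amine or a carboxylic acid, would give a step beyond the scatter remains open. Each compound also lies within the scatter of the next, so the set does not show whether any part of these structures moves this read-out.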